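Isobutoxy for Pentyl on the Carbonyl of Compound 2

A few compounds are considered here, and "the series" means these few. Any claim that something is new, unique, unknown or untested is made for them only; others in the source may bear on it.

Of the compounds shown here, three on a shared core have so far been measured in a functional assay on HL-60 cells (Homo sapiens) for inhibition, read by MTT assay, with a stated time of 72 h; a lower number here means a stronger inhibitor, a higher number a weaker inhibitor. Compound 1 `CC(Nc1nnc2nncn2n1)C(=O)O` gives 74300 nM in this assay. Compound 3 `c1nnc2nnc(N3CCCCC3)nn12` gives 23600 nM. Compound 2 `CCCCCC(=O)N1CCN(c2nnc3nncn3n2)CC1` gives 3610 nM, the lowest of the three numbers; its gap to compound 3 and its larger gap to compound 1 both lie beyond the usual scatter, so compound 2 stands as the strongest inhibitor among the measured set.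

Compound 4 `CC(C)COC(=O)N1CCN(c2nnc3nncn3n2)CC1` has not yet been measured. It differs from compound 2 in one place: isobutoxy in place of pentyl on a carbonyl carbon. Put one bond further out, the change reads pentylcarbonyl to isobutoxycarbonyl, so the carbonyl on the amide-type nitrogen in a ring is kept and only the group beyond it is exchanged.

Among the measured compounds shown here, no step between two measured compounds shows what such an exchange does on this core, so the expectation rests on compound 2 alone. The author expects the step from compound 2 to compound 4 to be small, a 1.5-fold higher number from compound 2 to compound 4 (0.18 log units; within the scatter), most likely within the scatter or a slight weakening. Compound 4 is therefore estimated at 5500 nM in this assay, with a range from 1800 nM to 17000 nM.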

Compound 4, half-maximal inhibitory concentration: 7930 nM
Compound 4: the middle estimate sits 1.4-fold (0.16 log units) below what was measured, and the stated range covers the measured number.
By their numbers in this assay, from the lowest: compound 2; then compound 4; then compound 3; then compound 1.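

In this assay, among the compounds shown here, this is the first reading of what an exchange on the carbonyl carbon does on the shared core: a 2.2-fold higher number from compound 2 to compound 4 (0.34 log units; beyond the scatter), a modest step, yet one that lies beyond the scatter. The position on the carbonyl carbon, whose other neighbour is the amide-type nitrogen in a ring, therefore registers a change even when the group that leaves and the group that enters both hold 5 heavy atoms and the carbonyl itself is kept. Nothing on hand accounts for the size or direction of this step.

For the compounds shown here, the single step cannot separate the oxygen that enters from the different arrangement of the carbons beyond it, so which of the two carries the change remains open. A straight butoxy group or a longer chain such as heptyl on the same carbonyl carbon would address that question, and a phenyl or a cyclohexyl group there would show whether the position also responds to a ring.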